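Bromoalkoxy chain to allyloxy: notes toward compound 3

This account rests on a few compounds, and the source may have more. Where it says the series, first, only, none or still open, it means among the compounds named here.

Two compounds of the series carry a measured number. Compound 1 `O=c1c(-c2ccc(O)cc2)coc2cc(OCCCCCCBr)ccc12` gives 71.2% in a functional assay on mitochondria (Cricetulus griseus) for inhibition of Monoamine oxidase (Homo sapiens), tested at 0.9 uM (a lower number here means a weaker effect, a higher number a stronger effect of the compound at the concentration tested), and compound 2 `O=c1c(-c2ccc(O)cc2)coc2cc(OCCCBr)ccc12` gives 67.7%. The step of a number 3.5 percentage points lower from compound 1 to compound 2 (within the scatter) is the only one available, and it sits within the scatter: cutting the bromoalkyl chain from six carbons to three, with the bromine kept at the end, changed nothing that can be read. Compound 2 therefore holds the lower of the two numbers, but its gap to compound 1 is within the scatter, so the two cannot be ordered.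

Compound 3 `C=CCOc1ccc2c(=O)c(-c3ccc(O)cc3)coc2c1` differs from compound 2 by vinyl in place of 2-bromoethyl on a saturated chain carbon bound to an oxygen on an aromatic ring. Unlike the measured step, this change removes the bromine altogether and ends the chain in a double bond, so no measured step bears on it directly; the measured step only shows that chain length within the bromoalkoxy pair hardly mattered. Among the measured compounds shown here, on that thin basis the step is expected to be small, with a slight lean downward because the one measured step of a number 3.5 percentage points lower from compound 1 to compound 2 (within the scatter) also went down a little, giving an expected a number 7.7 percentage points lower from compound 2 to compound 3 (within the scatter) in this assay. For compound 3 the estimated value is 60%, with a range of 40% to 76%.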

Compound 3, a percentage reported as inhibition, at one concentration (the size of the read-out at that concentration, not a potency): 68.8%
The estimate for compound 3 lay 8.8 percentage points below the measured number; low and high end bracket the measured number.
By their numbers in this assay, from the lowest: compounds 2, 3 and 1 (each within the scatter of the next).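

In this assay, the change from 3-bromopropoxy to allyloxy gives a number 1.1 percentage points higher from compound 2 to compound 3 (within the scatter), and the change from the longer bromoalkoxy chain to allyloxy gives a number 2.4 percentage points lower from compound 1 to compound 3 (within the scatter). The earlier pair varied only chain length and kept the bromine at the chain end, whereas these steps show that the bromine can be absent and a vinyl group can stand in place of 2-bromoethyl with no readable change in the inhibition at the concentration tested. All three compounds therefore lie within the scatter of one another, and nothing at hand accounts for this flat read-out at the chain on the oxygen.

All three chains shown are carbon chains ending in bromine or a double bond, so it stays open whether the read-out would remain flat with an amine or a carboxylic acid at the chain end, or with a methyl group in place of the whole chain. Also open, as far as these compounds go, is whether compounds that read alike at this single concentration would still read alike across a full concentration series.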